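A few compounds are considered here, and "the series" means these few. Any claim that something is new, unique, unknown or untested is made for them only; others in the source may bear on it.

Of the compounds shown here, three built on a shared core have been tested in a functional assay on 143B cells (Homo sapiens) for inhibition, read by CCK-8 assay, with a stated time of 72 h, tested at 1 uM; on this read-out higher numbers stand for more inhibition at the one concentration tested (going by the name of the read-out) and lower numbers for less inhibition. Compound 1 `COc1ccccc1N1C(=O)CSC1c1cc(F)cc(C(=O)O)c1` gives 0%, compound 3 `COc1ccccc1N1C(=O)CSC1C(=O)NCCCCc1ccccc1` gives 4%, and compound 2 `COc1ccc(C)cc1N1C(=O)CSC1c1cccc(C(=O)NCCCCc2ccccc2)c1` gives 29%. Compound 2 therefore stands highest of the three: its nearest neighbour is compound 3 and its furthest is compound 1, and both gaps lie beyond the usual scatter. Compound 4 `COc1cc(F)ccc1N1C(=O)CSC1c1cccc(C(=O)NCCCCc2ccccc2)c1` is a close relative of compound 2 that differs in a single place: 4-fluoro-2-methoxyphenyl in place of 2-methoxy-5-methylphenyl on an amide-type nitrogen in a ring. For the measured compounds named here, no measured pair shows this change on its own, so its effect in this assay is uncertain; a modest drop, or no step beyond the scatter, seems the most likely outcome. In this assay compound 4 is expected to give 22%, within a range from 8% to 40%. That corresponds to an expected step of a number 7 percentage points lower from compound 2 to compound 4 (within the scatter).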

Compound 4, a percentage reported as inhibition, at one concentration (the size of the read-out at that concentration, not a potency): 63%
Compound 4: the middle estimate sits 41 percentage points below what was measured; the whole stated range lies below it.
By their numbers in this assay, from the lowest: compounds 1 and 3 (each within the scatter of the next); then compound 2; then compound 4.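

In this assay putting 4-fluoro-2-methoxyphenyl in place of 2-methoxy-5-methylphenyl on the amide-type nitrogen gives a number 34 percentage points higher from compound 2 to compound 4 (beyond the scatter) with the rest of the molecule unchanged. For the compounds shown here, this is the first single-place comparison, and it shows that the read-out responds strongly to the aromatic group at this position. No measurement shown here explains the size of this step. The methyl leaves as the fluorine enters. Neither can be credited separately. A chlorine or an amine on that aromatic ring remains an open comparison.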